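Pyrazole amines with a pyridine-bearing acyl group

A few compounds are considered here, and "the series" means these few. Any claim that something is new, unique, unknown or untested is made for them only; others in the source may bear on it.

Measured so far, in an assay on Sf9 cells for inhibition of inhibitor of nuclear factor kappa-B kinase subunit epsilon (Homo sapiens), read by ADP-Glo, with a stated time of 60 min; a lower number here means a stronger inhibitor, a higher number a weaker inhibitor:
compound 1, `Cc1[nH]nc(N)c1-c1cccc(Br)c1`: > 100000 nM
compound 2, `Cc1[nH]nc(N)c1-c1ccc(Br)cc1`: > 100000 nM
compound 3, `CC(=O)n1nc(C)c(-c2ccc(Cl)c(Cl)c2)c1N`: > 100000 nM

For compound 3 this value is a limit of the assay, not a number. For compound 2 it is likewise a limit. For compound 1, too, the entry is a limit rather than a measured number. Compound 3 therefore stands at the limit of > 100000 nM in this assay, at which 3 of the 3 values shown sit, with no measured step between any two of these compounds to guide a direction.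

Compound 4, `Cc1nn(C(=O)c2ccncc2)c(N)c1-c1ccc(Cl)c(Cl)c1`, is not yet measured in this assay. It differs from compound 3 by pyridin-4-yl in place of methyl on a carbonyl carbon. For the measured compounds named here, with every recorded value a limit, no step within the set says whether such a change helps or hurts, so any expectation is weak. The expected step is an at least 2.0-fold lower number from compound 3 to compound 4 (0.30 log units; that floor lies within the scatter), downward but uncertain. In this assay compound 4 is expected to give 50000 nM, most likely between 5000 nM and 200000 nM, with a fair chance that only a limit is reported again.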

Compound 4, half-maximal inhibitory concentration: > 100000 nM
Compound 4: no number, only a limit; the forecaster's own chance of this, stated with the estimate: 60%; at least 2.0-fold (0.30 log units) between middle value and limit.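

The result for compound 4 is again a limit of the assay and not a number, like that of compound 3, so no step can be read for pyridin-4-yl in place of methyl on a carbonyl carbon: the limit of > 100000 nM in this assay, at which 4 of the 4 values shown sit.

The compounds shown leave open whether either group changes inhibition, and what a measured value for this series would be.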